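The source may hold more compounds than are shown below. What is called first, only, known or untested is meant among the compounds shown, and "the series" means these compounds.

Compound 1 `CCCC(=O)NC(c1ccc(C)cc1)c1cc(Cl)c2cccnc2c1O`: 120 nM
Compound 2 `CCCC(=O)NC(c1ccccc1Cl)c1cc(Cl)c2cccnc2c1O`: 100 nM

Within the data shown here, in a functional assay on A-375 cells (Homo sapiens) for antiproliferative activity, read by trypan blue exclusion and crystal violet staining, with a stated time of 72 h (a higher number here means a weaker inhibitor, a lower number a stronger inhibitor), compound 2, at 100 nM, stands level with compound 1, the only other compound measured so far. Compound 3 `CCCC(=O)NC(c1ccc(C(C)C)cc1)c1cc(Cl)c2cccnc2c1O` has not yet been measured. It carries 4-isopropylphenyl in place of 2-chlorophenyl on a saturated chain carbon bound to an amide-type nitrogen and an aromatic carbon. Among the measured compounds shown here, the one measured step that bears on this change sits at the same carbon and stays within the scatter: a 1.2-fold lower number from compound 1 to compound 2 (0.08 log units; within the scatter). For the measured compounds named here, no measured compound yet carries 4-isopropylphenyl, so this evidence is thin. On it, no step beyond the scatter is expected in this assay, in either direction. The estimate means an expected step of a 1.3-fold higher number from compound 2 to compound 3 (0.11 log units; within the scatter). For compound 3 the estimated value is 130 nM, with an expected range of 55 nM to 300 nM.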

Compound 3, half-maximal inhibitory concentration: 120 nM
Compound 3: middle estimate off by 1.1-fold (0.03 log units), on the high side; the range from low to high includes it.
By their numbers in this assay, from the lowest: compounds 2, 1 and 3 (each within the scatter of the next).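

In this assay, among these compounds, the step from methyl to isopropyl on an aromatic carbon, no change at the digits printed from compound 1 to compound 3 (within the scatter), gives the first reading of a change to the substituent alone while the 4-position of the phenyl name stays the same. The swap of 2-chlorophenyl for 4-isopropylphenyl on a saturated chain carbon bound to an amide-type nitrogen and an aromatic carbon, a 1.2-fold higher number from compound 2 to compound 3 (0.08 log units; within the scatter), also stays within the scatter, so all three aryl groups shown at this place read alike. Nothing on hand gives a reason for this sameness.

On these data alone, it remains open whether this place would still read alike with an amine or a carboxylic acid on the phenyl ring, or with cyclohexyl in place of that ring. As far as these compounds go, how a longer chain on the amide carbonyl would read is also open.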